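Bromo in Place of Methoxy: One Change, One Expectation

A few compounds are considered here, and "the series" means these few. Any claim that something is new, unique, unknown or untested is made for them only; others in the source may bear on it.

Measured so far:
compound 1 `COc1ccccc1-n1cc(COc2ccc3c(c2)CCC3)nn1` gives 19.8%
compound 2 `Cc1ccccc1NC(=O)Cn1cc(COc2ccc3c(c2)CCC3)nn1` gives "not determined" (no result reported)
compound 3 `O=C(Cn1cc(COc2ccc3c(c2)CCC3)nn1)Nc1ccccc1` gives "not determined" (no result reported)

For the measured compounds named here, in an ADME assay on HEK293 cells (Homo sapiens) for inhibition, read by MTT assay, with a stated time of 48 h, tested at 25 uM (on this read-out lower numbers stand for less inhibition and higher numbers for more inhibition at the one concentration tested (going by the name of the read-out)), compound 1 is the only compound with a number to its name; compound 2 and compound 3 carry no result, so compound 1 cannot be ranked against anything measured. The next entry, compound 4 `Brc1ccccc1-n1cc(COc2ccc3c(c2)CCC3)nn1`, differs from compound 1 by bromo in place of methoxy on an aromatic carbon. Going by the values given here, no measured pair in this set bridges that change, so nothing on record sets its size. The step from compound 1 to compound 4 is expected to be a number 2.2 percentage points higher from compound 1 to compound 4 (within the scatter), that is, nothing beyond the usual scatter of this read-out. Compound 4 is therefore estimated at 22%, with an expected range from 5% to 40%.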

Compound 4, a percentage reported as inhibition, at one concentration (the size of the read-out at that concentration, not a potency): 16.5%
Compound 4: middle estimate off by 5.5 percentage points, on the high side; the measured number falls inside the stated range.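

With a methoxy or a bromo on this aromatic carbon, ortho to a large group, this assay gives a number 3.3 percentage points lower from compound 1 to compound 4 (within the scatter), so the two compounds cannot be told apart. For the compounds shown here, this is the first measured pair to put a size on any change at this position, and it shows that this exchange, on the shared core, stays inside the usual scatter. Nothing on record offers an explanation for this result. On these data alone, it remains open whether an amine or a carboxylic acid on this carbon would take the read-out beyond the scatter. The same question stands for a longer chain in place of the methoxy.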